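A New Acid-Bearing Ring on Compound 2

The source may report more compounds than this note shows. Statements on the series, on what has been measured and on what is new or still open speak of the compounds shown alone.

In an ADME assay on the whole organism for metabolic stability, with Rattus norvegicus as the target, at a dose of 10 mg/kg by the intraperitoneal route (a lower number here means that the compound disappears faster, a higher number that the compound lasts longer), compound 1 (`COc1cc(C(=O)O)ccc1OCCCCOc1ccc(C(=O)CC(C)C)c(O)c1C`) gives 0.717 h and compound 2 (`Cc1c(OCCCCOc2ccc(F)c(C(=O)O)c2)ccc(C(=O)CC(C)(C)C)c1O`) gives 1.33 h in the same test. These two numbers lie within the usual scatter of each other. In compound 3 (`Cc1c(OCCCCOc2ccc(C(=O)CC(C)(C)C)c(O)c2C)cccc1C(=O)O`), 3-carboxy-2-methylphenyl stands in place of 3-carboxy-4-fluorophenyl on an oxygen on a saturated carbon (3-carboxy-2-methylphenyl in place of 3-carboxy-4-fluorophenyl on an oxygen on a saturated carbon). Among the compounds with values here, no measured pair shows what such a swap does, so no change beyond the scatter is expected in either direction. The expected move is a 1.1-fold lower number from compound 2 to compound 3 (0.04 log units; within the scatter) and no more. Compound 3 is estimated at 1.2 h with an expected range from 0.6 h to 2.4 h in this assay here.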

Compound 3, half-life: 1.77 h
Compound 3: middle estimate off by 1.5-fold (0.17 log units), on the low side, and the stated range covers the measured number.
By their numbers in this assay, from the lowest: compounds 1, 2 and 3 (each within the scatter of the next, the first and the last beyond it).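

In this assay, putting 3-carboxy-2-methylphenyl in place of 3-carboxy-4-fluorophenyl on an oxygen on a saturated carbon gives a 1.3-fold higher number from compound 2 to compound 3 (0.12 log units; within the scatter), a step within the scatter. At this position, then, this exchange of one acid-bearing ring for the other gives no change that can be told apart from repeat measurements. Nothing available here offers an explanation for this result. On these data alone, what a primary amide would do in place of the carboxylic acid on this ring remains open. So does the outcome for a ring carrying neither fluorine nor methyl.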